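Carbamate on the ring oxygen of compound 1

The compounds below may be only part of what the source reports. "The series", "measured", "known", "first", "only" and "open" are said of these compounds alone.

Compound 1 `CC(C)=CCC1Cc2c(O)cc(=O)n(CCCO)c2CC1(C)C` is the parent of the series. In a functional assay on PANC-1 cells (Homo sapiens) for inhibition, read by MTT assay, with a stated time of 24 h, tested at 10 uM (on this read-out higher numbers stand for more inhibition at the one concentration tested (going by the name of the read-out) and lower numbers for less inhibition), compound 1 gives 25.6%, the lowest of the three numbers measured. Among the measured compounds shown here, compound 2 `CC(C)=CCC1Cc2c(OCCCNS(=O)(=O)c3ccc([N+](=O)[O-])cc3)cc(=O)n(CCCO)c2CC1(C)C` gives 47.7% and compound 3 `CC(C)=CCC1Cc2c(OCCCNC(=O)c3ccc([N+](=O)[O-])cc3)cc(=O)n(CCCO)c2CC1(C)C` gives 49.9%; both lie beyond the scatter above compound 1, and the one measured step between them, a number 2.2 percentage points higher from compound 2 to compound 3 (within the scatter), is within the scatter. Compound 4 `COc1ccccc1NC(=O)Oc1cc(=O)n(CCCO)c2c1CC(CC=C(C)C)C(C)(C)C2` differs from compound 1 by (2-methoxyphenyl)carbamoyl in place of hydrogen on an oxygen on an aromatic ring. For the measured compounds named here, no measured step matches this change directly; the only guide is that both compounds in which that oxygen carries a substituent instead of hydrogen read well above compound 1. A gain of comparable size is therefore expected, a number 16.4 percentage points higher from compound 1 to compound 4 (beyond the scatter), with wide uncertainty. Compound 4 is estimated at 42%, range 24% to 60%.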

Compound 4, a percentage reported as inhibition, at one concentration (the size of the read-out at that concentration, not a potency): 71.1%
For compound 4 the middle estimate is 29.1 percentage points below the measured one; measured number outside the range, above it.
By their numbers in this assay, from the lowest: compound 1; then compounds 2 and 3 (each within the scatter of the next); then compound 4.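

In this assay, (2-methoxyphenyl)carbamoyl in place of hydrogen on the oxygen on an aromatic ring gives a large gain, a number 45.5 percentage points higher from compound 1 to compound 4 (beyond the scatter). This position therefore accepts a carbamoyl group placed directly on that oxygen, and compound 4 at 71.1% reads above compound 3 at 49.9%, so a propyl chain ending in a (4-nitrophenyl)carbonyl amide is not required for a high reading. Nothing on hand explains the size of this gain. From the compounds shown here alone, it remains open whether the methoxy group contributes, which phenylcarbamoyl would test, and whether dimethylcarbamoyl, without the aromatic ring, keeps the gain.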